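The source may report more compounds than this note shows. Statements on the series, on what has been measured and on what is new or still open speak of the compounds shown alone.

The series is followed in an assay on Sf9 cells for inhibition of Leucine-rich repeat serine/threonine-protein kinase 2 (Homo sapiens), read by TR-FRET, with stated times of 30 min and 2 h; on this read-out lower numbers stand for stronger inhibition and higher numbers for weaker inhibition. Compound 1 `O=C(Nc1ccnnc1)c1cc(N2C[C@H]3COC[C@H]3C2)ccc1OCc1ccccc1` gives 50.1 nM in this assay. Compound 2 `O=C(Nc1cccc(Cl)c1)c1cc(C(F)(F)F)ccc1OCc1ccc(F)cc1` gives 12.6 nM, and compound 3 `O=C(Nc1cccnc1)c1cc(C(F)(F)F)ccc1OCc1ccccc1` gives 12.6 nM; these two numbers lie within the scatter of each other, whereas compound 1 stands above both by a margin beyond the scatter and so shows the weakest inhibition of the three. For the measured compounds named here, no two measured compounds differ in one place only, so no single structural step has a measured size here.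

Compound 4 `O=C(Nc1ccnnc1)c1cc(N2CCNCC2)ccc1OCc1ccccc1` arises from compound 1 by one change: a group of 6 heavy atoms (4 carbon, 2 nitrogen; one six-membered non-aromatic ring with 2 hetero atoms) in place of a group of 8 heavy atoms (6 carbon, 1 nitrogen, 1 oxygen; 2 five-membered non-aromatic rings with 1 hetero atom each), on an aromatic carbon. Going by the values given here, nothing among the measured compounds speaks directly to this replacement; compound 2 and compound 3 carry a trifluoromethyl group rather than either ring system and have different amide partners, so they give no guide to the size or direction of the step. On that footing the step from compound 1 to compound 4 is expected to be small, at most around the edge of the scatter, with no firm direction, a 1.3-fold higher number from compound 1 to compound 4 (0.10 log units; within the scatter). Compound 4 is therefore estimated at 63 nM in this assay, within a range from 20 nM to 200 nM.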

Compound 4, half-maximal inhibitory concentration: 15.9 nM
Beside the measured number, compound 4's estimate is 4.0-fold (0.60 log units) above it, and the stated range ends above it.
By their numbers in this assay, from the lowest: compounds 2, 3 and 4 (each within the scatter of the next); then compound 1.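

For the compounds shown here, the first comparison that differs in one place falls on the aromatic carbon meta to a (pyridazin-4-yl)carbamoyl group and para to a benzyloxy group, and it shows that the ring carried there matters in this assay: piperazin-1-yl, in place of the group with 2 five-membered non-aromatic rings, gives a 3.2-fold lower number from compound 1 to compound 4 (0.50 log units; beyond the scatter). The exchange also takes the substituent from 0 hydrogen-bond donors to 1 hydrogen-bond donor and from 8 heavy atoms to 6 heavy atoms, but this one step cannot separate those differences from each other. No measurement shown here accounts for the size or direction of the step.

The compounds shown leave open whether the step depends on the hydrogen-bearing ring nitrogen of piperazin-1-yl, as a comparison with 4-methylpiperazin-1-yl or morpholin-4-yl at this position would test. They also leave open how piperazin-1-yl and trifluoromethyl compare at this position with the same amide partner and the same benzyloxy group.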